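The compounds below may be only part of what the source reports. "The series", "measured", "known", "first", "only" and "open" are said of these compounds alone.

Compound 1, `C/C(=C\CCCCC(=O)O)c1cccnc1`, gives the highest number of the three measured compounds in an assay (Equus caballus) for inhibition of Thromboxane-A synthase (Homo sapiens), using microsomes (on this read-out lower numbers stand for stronger inhibition and higher numbers for weaker inhibition), where compound 1 gives 210 nM. Within the data shown here, its nearest neighbour is compound 3, `C/C(=C/CCCCC(=O)O)c1cccnc1`, which in this assay gives 71 nM; the step of a 3.0-fold lower number from compound 1 to compound 3 (0.47 log units; beyond the scatter) is the only single-change step among the measured compounds, and the basis for reading it lies in the fact that compounds 1 and 3 differ only in the configuration as drawn. Among the measured compounds shown here, compound 2, `CC(C)(O)C(CCC/C=C(\c1ccccc1)c1cccnc1)C(=O)O`, gives 42 nM in this assay, the lowest of the three numbers, but it differs from compound 1 in more than one place, so no single step joins them and the two values can only be set side by side.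

Compound 4, `O=C(O)CCCC/C=C(/c1cccnc1)c1cccs1`, is reached from compound 1 by one change: thiophen-2-yl in place of methyl on a double-bonded chain carbon bound to an aromatic carbon and a double-bonded chain carbon. For the measured compounds named here, none of the measured steps involves a swap of this kind; the one measured step alters only the drawn geometry of the double bond and leaves every group in place, so it offers no direct guide to the size or direction of this change. What the numbers do show is that the compound carrying more than a methyl at that position, compound 2, sits well below compound 1. On that slender basis a modest lowering is expected rather than a large one. Compound 4 is therefore estimated at 100 nM, within a range from 25 nM to 400 nM, which corresponds to an expected step of a 2.1-fold lower number from compound 1 to compound 4 (0.32 log units; beyond the scatter).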

Compound 4, half-maximal inhibitory concentration: 54 nM
Compound 4: the middle estimate sits 1.9-fold (0.27 log units) above what was measured, and the stated range covers the measured number.
By their numbers in this assay, from the lowest: compounds 2, 4 and 3 (each within the scatter of the next); then compound 1.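

At the double-bonded chain carbon bound to an aromatic carbon and a double-bonded chain carbon, replacing methyl with thiophen-2-yl gives a 3.9-fold lower number from compound 1 to compound 4 (0.59 log units; beyond the scatter) in this assay. Among these compounds, this is the first measured step that changes a group at this position, since the earlier single-change step altered only the drawn geometry of the double bond. It shows that methyl is not needed here to keep inhibition in this assay: a group of five heavy atoms containing a five-membered aromatic ring can take the place of a single carbon, and the number falls rather than rises. Nothing given here explains why the number falls, whether the ring as a whole or its sulfur is responsible.

On these data alone, with a single replacement measured at this position, it remains open whether a small chain such as ethyl would already lower the number or whether an aromatic ring is needed. As far as these compounds go, it is also open whether a furan-2-yl ring, with oxygen in place of sulfur, would give a similar step, and how the opposite double-bond geometry would behave with thiophen-2-yl in place.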